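Compound 4 after three readings at the limit

This account rests on a few compounds, and the source may have more. Where it says the series, first, only, none or still open, it means among the compounds named here.

Within the data shown here, the series so far holds three compounds, and none of them yields a number. Compound 1 (`NC(=O)C(=O)NCCCCCCCC(=O)Nc1ccccc1`) gives > 100000 nM in a functional assay on HCT-116 cells (Homo sapiens) for inhibition, read by colorimetric assay, with a stated time of 3 days (on this read-out higher numbers stand for weaker inhibition and lower numbers for stronger inhibition), as a limit of the assay. Compound 2 (`NC(=O)C(=O)NCCCCCC(=O)Nc1ccccc1`) gives > 100000 nM in this assay as a limit too. Compound 3 (`C/C(=N\O)C(=O)NCCCCCCC(=O)Nc1ccccc1`) gives > 100000 nM in this assay as a limit as well, so its standing is that limit and no more. The whole record reads as the limit of > 100000 nM in this assay, at which 3 of the 3 values shown sit, and nothing in it separates the compounds.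

Compound 4 (`O=C(CCCCCCC(O)C(F)(F)F)Nc1ccccc1`) has not yet been measured. Its change from compound 3 is this: a group of 6 heavy atoms (2 carbon, 1 oxygen, 3 fluorine; no ring) in place of a group of 7 heavy atoms (3 carbon, 2 nitrogen, 2 oxygen; no ring), on a saturated chain carbon, six bonds along the chain from a carbonyl carbon with 2,2,2-trifluoro-1-hydroxyethyl entering on a saturated chain carbon, six bonds along the chain from a carbonyl carbon.

Among the measured compounds shown here, the one measured step at that place is a step that the two limits leave unreadable from compound 1 to compound 3 and it offers no size to carry over. No step beyond the scatter is therefore expected in this assay and no direction can be argued. The estimated move is a number no higher from compound 3 to compound 4 (the limit leaves the size open) as an expectation only. Compound 4 is estimated at 100000 nM with an expected range of 30000 nM to 200000 nM and a reading at the limit is the likeliest outcome.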

Compound 4, half-maximal inhibitory concentration: > 40000 nM
Compound 4: a limit, no number; the forecaster's own chance of this, stated with the estimate: 75%; the middle value lies beyond the limit too.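

In this assay compound 4 gives > 40000 nM, a limit and not a number. Among these compounds, with compound 1, compound 2 and compound 3 also recorded only as limits, no step from any of them to compound 4 can be read. The compounds shown leave open whether any of the four has a measurable potency in this assay and how they rank.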